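From furan-2-yl to thiophen-3-yl on compound 3

The source may report more compounds than this note shows. Statements on the series, on what has been measured and on what is new or still open speak of the compounds shown alone.

In a functional assay on HCT-116 cells (Homo sapiens), read by MTT assay, with a stated time of 72 h (a higher number here means a weaker inhibitor, a lower number a stronger inhibitor), compound 1 `COc1ncnc2c1c(-c1cc3ccccc3o1)cn2[C@@H]1O[C@H](CO)[C@@H](O)[C@H]1O` gives 14500 nM. Compound 2 `CSc1ncnc2c1c(-c1ccccc1)cn2[C@@H]1O[C@H](CO)[C@@H](O)[C@H]1O` reads > 20000 nM, which is a limit and not a number. Compound 3 `CNc1ncnc2c1c(-c1ccco1)cn2[C@@H]1O[C@H](CO)[C@@H](O)[C@H]1O` gives 440 nM, the lower of the two actual numbers, and the gap to compound 1, which gives 14500 nM, lies beyond the scatter. Compound 4 `CNc1ncnc2c1c(-c1ccsc1)cn2[C@@H]1O[C@H](CO)[C@@H](O)[C@H]1O` has thiophen-3-yl in place of furan-2-yl on an aromatic carbon. Among the measured compounds shown here, no measured pair isolates this kind of change, so the expectation in this assay starts from compound 3 at 440 nM, with a slightly higher number but no step beyond the scatter. The expected step is a 1.4-fold higher number from compound 3 to compound 4 (0.13 log units; within the scatter). For compound 4 the estimated value is 600 nM, with an expected range of 150 nM to 3000 nM.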

Compound 4, half-maximal inhibitory concentration: > 20000 nM
Compound 4: only a limit was reported (the forecaster's own chance of this, stated with the estimate: 3%); middle value at least 33-fold (1.52 log units) away from the limit.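

In this assay, among the compounds shown here, the change from furan-2-yl to thiophen-3-yl gives an at least 45-fold higher number from compound 3 to compound 4 (1.65 log units; beyond the scatter), the first step that isolates one place, and it comes with equal counts of heavy atoms, donors and acceptors in the two groups. This aromatic carbon of the shared core therefore does not accept every five-membered aromatic ring with 1 hetero atom. Compound 4 reads > 20000 nM, which is a limit and not a number: the limit of > 20000 nM in this assay, at which 2 of the 4 values shown sit.

Still open, going by these compounds, is whether the step follows the oxygen-to-sulfur exchange or the changed point of attachment. Thiophen-2-yl or furan-3-yl on the core of compound 3 would separate the two.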